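The compounds below may be only part of what the source reports. "The series", "measured", "known", "first", "only" and "open" are said of these compounds alone.

Measured in an ADME assay on microsomes from liver (Rattus norvegicus) for metabolic stability; a lower number here means that the compound disappears faster, a higher number that the compound lasts longer:
- compound 1 `CC(C)C(Nc1nnc[nH]1)c1ccc(-c2ccc3cccc(F)c3c2)[nH]c1=O`: 1.29 h
- compound 2 `CCn1ncc2c(F)cc(-c3ccc(C(CC)(CC)c4nnc[nH]4)c(=O)[nH]3)cc21`: > 3 h, a limit
- compound 3 `CCn1ncc2c(F)cc(-c3ccc(C(CC)(CC)c4nncn4C)c(=O)[nH]3)cc21`: > 3 h, a limit

For the measured compounds named here, compound 1 holds the only actual number in this assay, at 1.29 h. The rest of the series offers only (the limit of > 3 h in this assay, at which 2 of the 3 values shown sit).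

Compound 4 `CC(C)C(Nc1nccs1)c1ccc(-c2ccc3cccc(F)c3c2)[nH]c1=O` changes one place of compound 1: 1,3-thiazol-2-yl in place of 4H-1,2,4-triazol-3-yl on an amine nitrogen. Going by the values given here, the only measured step, a step that the two limits leave unreadable from compound 2 to compound 3, is a different change and cannot be read, so it gives no size and no direction for this one. With no measured support, nothing beyond the scatter is expected, and the expected step is a 1.2-fold lower number from compound 1 to compound 4 (0.07 log units; within the scatter). For compound 4 the estimated half-life is 1.1 h, with an expected range of 0.4 h to 2.6 h.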

Compound 4, half-life: 0.07 h
For compound 4 the middle estimate is 16-fold (1.20 log units) above the measured one, outside the stated range (below it).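

In this assay the group on the amine nitrogen of compound 1 matters: 1,3-thiazol-2-yl in place of 4H-1,2,4-triazol-3-yl gives an 18-fold lower number from compound 1 to compound 4 (1.27 log units; beyond the scatter) with the rest of the molecule unchanged. For the compounds shown here, this is the only readable step; the pair compound 2 and compound 3 rests on two limits and cannot be read. Nothing measured in the series accounts for this step.

Open, as far as these compounds go, is whether the sulfur or the lost ring nitrogens carry the step. Also open, from the compounds shown here alone, is how a pyrazole or an oxazole on this amine nitrogen would read.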